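Changing the amide group in a clearance series

A few compounds are considered here, and "the series" means these few. Any claim that something is new, unique, unknown or untested is made for them only; others in the source may bear on it.

Going by the values given here, in an in vitro ADME assay on microsomes from liver (Homo sapiens) for pharmacokinetics, read by LC-MS, with a stated time of 10 min, tested at 1 uM (on this read-out higher numbers stand for fast clearance and lower numbers for slow clearance), compound 1 `COc1ccc(NC(=O)[C@H]2CN(C)C[C@@H]2c2ccc(/C=C/C(=O)Nc3ccccc3N)cc2)cc1` gives 14 mL/min/kg and compound 2 `CN1C[C@H](C(=O)Nc2ccc(F)c(Br)c2)[C@@H](c2ccc(/C=C/C(=O)Nc3ccccc3N)cc2)C1` gives 15 mL/min/kg, so compound 2 stands level with its only neighbour. Compound 3 `Cc1ccc(NC(=O)[C@H]2CN(C)C[C@@H]2c2ccc(/C=C/C(=O)Nc3ccccc3N)cc2)cn1` brings a change at the same place: 6-methylpyridin-3-yl in place of 3-bromo-4-fluorophenyl on an amide-type nitrogen. Among the compounds with values here, the one measured step there, a 1.1-fold higher number from compound 1 to compound 2 (0.03 log units; within the scatter), stayed within the scatter. Within the data shown here, that is a single step, and no measured compound carries a ring with a hetero atom at this place. The expected step in this assay is therefore no change at the digits printed from compound 2 to compound 3 (within the scatter), none beyond the scatter. The estimated clearance of compound 3 is 15 mL/min/kg, with an expected range of 8 mL/min/kg to 28 mL/min/kg.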

Compound 3, clearance: 8 mL/min/kg
For compound 3 the middle estimate is 1.9-fold (0.27 log units) above the measured one; the measured number falls inside the stated range.
By their numbers in this assay, from the lowest: compounds 3, 1 and 2 (each within the scatter of the next).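

With 6-methylpyridin-3-yl, a ring with a hetero atom now sits on the amide-type nitrogen, and the comparison reads a 1.9-fold lower number from compound 2 to compound 3 (0.27 log units; within the scatter) and a 1.8-fold lower number from compound 1 to compound 3 (0.24 log units; within the scatter). Three different aromatic rings at this place have therefore given no clearance step beyond the scatter, including the first with a hydrogen-bond acceptor in this group. No evidence on the reason for these values is available. Still open, as far as these compounds go, is whether a plain pyridin-3-yl without the methyl would fit the same picture, and whether a non-aromatic group here, such as a piperidine ring or a longer alkyl chain, would stay within the scatter.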